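A few compounds are considered here, and "the series" means these few. Any claim that something is new, unique, unknown or untested is made for them only; others in the source may bear on it.

Three compounds of the series carry numbers in a functional assay on U2OS cells (Homo sapiens) for antiproliferative activity, read by MTT assay, with a stated time of 72 h; on this read-out higher numbers stand for weaker inhibition and lower numbers for stronger inhibition. Compound 1 `Cc1cc(C)cc(C(=O)Nc2nc3ccc(NC(=O)CSc4ccc(Cl)cc4)cc3s2)c1` returns only a limit of the assay, > 100000 nM. Compound 2 `CCCC(=O)Nc1nc2ccc(NC(=O)CSc3cccc(O)c3)cc2s1` gives 10100 nM. On the numbers shown, compound 3 `O=C(CSc1cccc(O)c1)Nc1ccc2nc(NC(=O)c3ccc(F)cc3)sc2c1` stands at 5120 nM, with the step of a 2.0-fold lower number from compound 2 to compound 3 (0.30 log units; within the scatter) lying within the scatter, so compound 2 and compound 3 are not separated. Compound 4 `Cc1ccc(C(=O)Nc2nc3ccc(NC(=O)CSc4cccc(O)c4)cc3s2)cc1` awaits measurement and differs from compound 3 by methyl in place of fluoro on an aromatic carbon. Among the compounds with values here, no measured step touches a substituent on that ring; the single step available, a 2.0-fold lower number from compound 2 to compound 3 (0.30 log units; within the scatter), is a change at the same carbonyl and was itself within the scatter. The step of a 1.0-fold lower number from compound 3 to compound 4 (0.01 log units; within the scatter) is therefore expected to stay within the scatter, in no fixed direction. Compound 4 is estimated at 5000 nM, within a range of 2000 nM to 15000 nM.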

Compound 4, half-maximal inhibitory concentration: 12400 nM
For compound 4 the middle estimate is 2.5-fold (0.39 log units) below the measured one; measured number inside the range.
By their numbers in this assay, from the lowest: compounds 3, 2 and 4 (each within the scatter of the next, the first and the last beyond it). At a limit, above all of these: compound 1.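

Methyl in place of fluoro, para to a large group on the aromatic ring, gives a 2.4-fold higher number from compound 3 to compound 4 (0.38 log units; beyond the scatter), the first step at this ring position and one that separates two compounds in this assay. At the carbonyl carbon, 4-methylphenyl in place of propyl gives a 1.2-fold higher number from compound 2 to compound 4 (0.09 log units; within the scatter), so neither aryl group shown is separated from propyl. Nothing shown bears on the cause of the step at the ring.

From the compounds shown here alone, how an amine, a methoxy group or a carboxylic acid at this position would compare remains open.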